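Halogen change on the benzyl group of compound 1

The compounds below may be only part of what the source reports. "The series", "measured", "known", "first", "only" and "open" are said of these compounds alone.

compound 1 `OC[C@H]1O[C@@H](n2cnc3c(NCc4ccccc4F)ncnc32)[C@H](O)[C@@H]1O`: 3200 nM
compound 2 `OC[C@H]1O[C@@H](n2cnc3c(NCc4ccccc4Cl)ncnc32)[C@H](O)[C@@H]1O`: 1600 nM

Going by the values given here, the only measured step in a functional assay on HL-60 cells (Homo sapiens) for antiproliferative activity, with a stated time of 72 h (a higher number here means a weaker inhibitor, a lower number a stronger inhibitor), is a 2.0-fold lower number from compound 1 to compound 2 (0.30 log units; within the scatter), with chloro in place of fluoro on an aromatic carbon. Among the compounds with values here, compound 1 therefore stands level with its one measured neighbour, and the two values give no order.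

Compound 3 `OC[C@H]1O[C@@H](n2cnc3c(NCc4ccc(Br)cc4)ncnc32)[C@H](O)[C@@H]1O` has not yet been measured. Its difference from compound 1 is 4-bromophenyl in place of 2-fluorophenyl on a saturated chain carbon bound to a nitrogen on an aromatic ring. Within the data shown here, the measured step bears on this only in part, as no measured compound carries 4-bromophenyl. Going by that one small step, no change beyond the scatter is expected in this assay, and the direction stays open, with only a slight lean towards a lower number. The expected step is a 1.5-fold lower number from compound 1 to compound 3 (0.16 log units; within the scatter). Compound 3 is estimated at 2200 nM, with an expected range of 800 nM to 6500 nM.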

Compound 3, half-maximal inhibitory concentration: 47400 nM
Beside the measured number, compound 3's estimate is 22-fold (1.33 log units) below it, and the stated range ends below it.
By their numbers in this assay, from the lowest: compounds 2 and 1 (each within the scatter of the next); then compound 3.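

In this assay, the halogen exchange between compound 1 and compound 2 left the number within the scatter, but this position proves far from indifferent to the aryl group it carries. With 4-bromophenyl in place of 2-fluorophenyl on the saturated chain carbon, the result is a 15-fold higher number from compound 1 to compound 3 (1.17 log units; beyond the scatter) and with 4-bromophenyl in place of 2-chlorophenyl it is a 30-fold higher number from compound 2 to compound 3 (1.47 log units; beyond the scatter) so the change costs much activity against either earlier compound. Nothing available accounts for this loss.

Compound 3 changes both the halogen and its place on the phenyl ring, so the compounds shown do not separate these two changes. 2-Bromophenyl and 4-fluorophenyl would separate them, while unsubstituted phenyl would show how the halogens compare with hydrogen at this position.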